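The compounds below may be only part of what the source reports. "The series", "measured", "known", "first", "only" and "open" are said of these compounds alone.

Compounds measured in a functional assay on A549 cells (Homo sapiens) for antiproliferative activity, read by MTT assay, with a stated time of 72 h; on this read-out lower numbers stand for stronger inhibition and higher numbers for weaker inhibition:
Compound 1, `COc1c(NS(=O)(=O)C2CC2)cc(-c2ccc3nc(NC(=O)C4CC4)sc3c2)cc1C(N)=O`: 46300 nM
Compound 2, `COc1c(NS(=O)(=O)c2ccc(F)cc2)cc(-c2ccc3nc(NC(=O)C4CC4)sc3n2)cc1C(N)=O`: 8050 nM
Compound 3, `COc1c(NS(=O)(=O)c2ccc(F)cc2)cc(-c2ccc3nc(NC(=O)C4CC4)nn3c2)cc1C(N)=O`: "not determined" (no result reported)

On the two numbers at hand, compound 1 gives the highest value in this assay, and its nearest neighbour, compound 2, gives a lower number that lies beyond the usual scatter. Compound 3 contributes no number. Compound 4, `COc1c(NS(=O)(=O)c2ccc(F)cc2)cc(-c2ccc3nc(NC(=O)C4CC4)sc3c2)cc1C(N)=O`, keeps the core of compound 1 and changes only the sulfonamide: 4-fluorophenyl in place of cyclopropyl on a sulfonyl sulfur. Compound 2 carries the same ((4-fluorophenyl)sulfonyl)amino group and gives the lower number, yet its core differs from that of compound 1, so no comparison of a single change is available, and the direction and size of this step rest on a loose analogy. A modest downward step is expected, roughly a 3.1-fold lower number from compound 1 to compound 4 (0.49 log units; beyond the scatter), though the outcome could also stay within scatter of compound 1. Compound 4 is estimated at 15000 nM in this assay, with a range from 4000 nM to 50000 nM.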

Compound 4, half-maximal inhibitory concentration: 6340 nM
Compound 4: middle estimate off by 2.4-fold (0.37 log units), on the high side; the measured number falls inside the stated range.
By their numbers in this assay, from the lowest: compounds 4 and 2 (each within the scatter of the next); then compound 1.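

On the core of compound 1, the group on the sulfonyl sulfur turns out to matter by itself: in this assay, 4-fluorophenyl in place of cyclopropyl gives a 7.3-fold lower number from compound 1 to compound 4 (0.86 log units; beyond the scatter). Among these compounds, earlier, the only number with this ((4-fluorophenyl)sulfonyl)amino group came from compound 2, whose core also differs, so this is the first reading of the change at this position alone. Nothing measured here accounts for the size or direction of the step.

Whether the lower number comes from the fluorine or from the aromatic ring remains open, as the compounds shown include no plain phenyl on the sulfonyl sulfur. Also open, from the compounds shown here alone, is how a small methyl or a longer chain such as n-butyl would compare there, and whether the step would carry over to other cores.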